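Methoxyethoxy in place of cyclopropylamino on the shared core

A few compounds are considered here, and "the series" means these few. Any claim that something is new, unique, unknown or untested is made for them only; others in the source may bear on it.

Compound 2 `Nc1nc(NC2CC2)c2ncn(/C=C3/CC3(CO)CO)c2n1` in an ADME assay on HFF cells (Homo sapiens) for cytotoxicity, with a stated time of 8 days (on this read-out lower numbers stand for higher toxicity in this test and higher numbers for lower toxicity in this test), gives > 300000 nM; this value is a limit of the assay, not a number. Compound 1 `Nc1nc(NC2CCCCC2)c2ncn(/C=C3/CC3(CO)CO)c2n1` in this assay gives > 300000 nM, again a limit. Compound 3 `CN(C)c1nc(N)nc2c1ncn2/C=C1/CC1(CO)CO` gives > 300000 nM, also a limit. All three values share (the limit of > 300000 nM in this assay, at which 3 of the 3 values shown sit), so the measured steps carry no readable size: a step that the two limits leave unreadable from compound 1 to compound 2, a step that the two limits leave unreadable from compound 1 to compound 3 and a step that the two limits leave unreadable from compound 2 to compound 3.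

Compound 4 `COCCOc1nc(N)nc2c1ncn2/C=C1/CC1(CO)CO` differs from compound 2 in one place: 2-methoxyethoxy in place of cyclopropylamino on an aromatic carbon.

Within the data shown here, the steps that bear on this change are those among compounds 1, 2 and 3, and none of them yields a size or a direction. The measured set therefore gives no ground to expect a step beyond the scatter in this assay, and no ground to expect one in either direction; the change from cyclopropylamino to 2-methoxyethoxy is simply untested here. Compound 4 is expected to sit at 400000 nM, with a range from 100000 nM to 1500000 nM, most likely reported again only as a limit. The step this estimate means from compound 2 to compound 4 is expected to be a step that the limit leaves unreadable from compound 2 to compound 4.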

Compound 4, half-maximal cytotoxic concentration: > 300000 nM
Compound 4 was reported as a limit; the forecaster's own chance of this, stated with the estimate: 80%; the middle value lies beyond the limit too.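

No step to compound 4 from compound 1, compound 2 or compound 3 can be read in this assay, because all four values sit at one limit: the limit of > 300000 nM in this assay, at which 4 of the 4 values shown sit.

The compounds shown leave open how far each lies beyond that limit, and whether any group on this aromatic carbon brings a readable cytotoxic concentration.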